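The source may hold more compounds than are shown below. What is called first, only, known or untested is meant among the compounds shown, and "the series" means these compounds.

Measured in a functional assay on DU-145 cells (Homo sapiens) for inhibition, read by trypan blue exclusion, with a stated time of 96 h; on this read-out higher numbers stand for weaker inhibition of growth and lower numbers for stronger inhibition of growth:
- compound 1 `O=C(/C(=C\c1ccc(Br)c([N+](=O)[O-])c1)Sc1ccc(Br)cc1)c1ccc(Br)cc1`: 1000 nM
- compound 2 `O=C(/C(=C\c1ccc(Br)c([N+](=O)[O-])c1)S(=O)(=O)c1ccc(Br)cc1)c1ccc(Br)cc1`: 10000 nM

Of these two compounds, compound 1 holds the lower number, and compound 2 is its nearest neighbour. Compound 3 `O=C(/C(=C\c1ccc(O)c([N+](=O)[O-])c1)Sc1ccc(Br)cc1)c1ccc(Br)cc1` has not yet been measured. Its change from compound 1 is hydroxy in place of bromo on an aromatic carbon, ortho to a nitro group and para to a large group. Among the compounds with values here, the only measured step is a 10-fold higher number from compound 1 to compound 2 (1.00 log units; beyond the scatter), where (4-bromophenyl)sulfonyl replaces (4-bromophenyl)sulfanyl. Within the data shown here, that change lies at a different place, so it shows only that this core can respond. Among the measured compounds shown here, no measured step touches the bromo, so the direction is uncertain in this assay; a small rise is expected, smaller than the step to compound 2. For compound 3 the estimated value is 1500 nM, with an expected range of 300 nM to 8000 nM. The expected change is a 1.5-fold higher number from compound 1 to compound 3 (0.18 log units; within the scatter).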

Compound 3, concentration for 50% growth inhibition: 1000 nM
Compound 3: middle estimate off by 1.5-fold (0.18 log units), on the high side; the range from low to high includes it.
By their numbers in this assay, from the lowest: compounds 1 and 3 (each within the scatter of the next); then compound 2.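

In this assay, hydroxy in place of bromo on the aromatic carbon ortho to a nitro group gives no change at the digits printed from compound 1 to compound 3 (within the scatter). Within the data shown here, this is the first reading at this position, and it shows that the bromo is not required for growth inhibition at this level, even though hydroxy brings a hydrogen-bond donor and acceptor that bromo lacks; the sulfur change elsewhere on the core, by contrast, gave a 10-fold higher number from compound 1 to compound 2 (1.00 log units; beyond the scatter). No supporting data bear on why bromo and hydroxy read alike here.

On these data alone, whether this position would accept other groups, such as an amine, a methoxy group or a carboxylic acid, remains open. As far as these compounds go, it is also open whether hydroxy in place of bromo would read the same way on the sulfonyl compound 2.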